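Working notes: replacing the group on the carbonyl carbon

A few compounds are considered here, and "the series" means these few. Any claim that something is new, unique, unknown or untested is made for them only; others in the source may bear on it.

- compound 1 `O=C(NCc1ccc(S(=O)(=O)N2CCCCC2)cc1)c1cc2cnccc2o1` with 46%
- compound 2 `O=C(NCc1ccc(S(=O)(=O)N2CCCCC2)cc1)c1cc2ccncc2[nH]1` with 50%

For the measured compounds named here, both numbers come from an ADME assay on microsomes from liver (Homo sapiens) for metabolic stability, read by LC-MS, with a stated time of 30 min, tested at 1 uM (a higher number here means that more of the compound is left, a lower number that less of the compound is left), and they cannot be separated: compound 2 stands within the scatter of compound 1 and no other measured compound is available for comparison.

Compound 3 `O=C(NCc1ccc(S(=O)(=O)N2CCCCC2)cc1)c1cnc2nccn2c1` has not yet been measured. Its difference from compound 2 is a group of 9 heavy atoms (6 carbon, 3 nitrogen; one five-membered aromatic ring with 2 hetero atoms, one six-membered aromatic ring with 2 hetero atoms) in place of a group of 9 heavy atoms (7 carbon, 2 nitrogen; one five-membered aromatic ring with 1 hetero atom, one six-membered aromatic ring with 1 hetero atom), on a carbonyl carbon and the place is again the carbonyl carbon of the amide.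

Going by the values given here, only one measured step bears on this change, an exchange at the same kind of place: a number 4 percentage points higher from compound 1 to compound 2 (within the scatter) is all that the series shows so far. Among the compounds with values here, this is thin evidence, as no compound carrying the entering group has been measured. With that single step as the guide, no shift beyond the scatter is expected in this assay and the range is kept wide. The expected step is a number 2 percentage points lower from compound 2 to compound 3 (within the scatter) and this is an estimate only. For compound 3 the estimated value is 48% (expected range 27% to 68%).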

Compound 3, percent of the compound remaining: 64%
Beside the measured number, compound 3's estimate is 16 percentage points below it; low and high end bracket the measured number.
By their numbers in this assay, from the lowest: compounds 1 and 2 (each within the scatter of the next); then compound 3.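

Working notes: reading the new step

The group on the carbonyl carbon of the amide can move this read-out after all: this assay shows a number 14 percentage points higher from compound 2 to compound 3 (beyond the scatter) and a number 18 percentage points higher from compound 1 to compound 3 (beyond the scatter) for the same entering group, whereas the earlier exchange between compound 1 and compound 2 stayed within the scatter. The leaving and entering groups in the step to compound 3 both have 9 heavy atoms, so a change in heavy-atom count plays no part; the exchange swaps a carbon for a nitrogen and goes from 1 hydrogen-bond donor and 1 hydrogen-bond acceptor to 0 hydrogen-bond donors and 3 hydrogen-bond acceptors. Nothing available ties the higher number to any one of these differences or gives a cause for it.

With a single compound carrying the entering group, the series does not show which of its nitrogens or which of its two rings goes with the step. It also leaves open whether a methyl group, a fluorine or an amine on that group would keep, raise or lower the number in this assay when the rest of the structure stays the same.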